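A few compounds are considered here, and "the series" means these few. Any claim that something is new, unique, unknown or untested is made for them only; others in the source may bear on it.

Three esters sharing one core have been tested in a functional assay on SK-LU-1 cells (Homo sapiens) for antiproliferative activity, read by sulforhodamine B assay, with a stated time of 48 h, tested at 50 uM; a lower number here means less inhibition, a higher number more inhibition at the concentration tested (going by the name of the read-out). Compound 1 `COc1cccc(C(=O)Oc2cc3c(cc2C)[C@@H](C(C)C)CC=C3C)c1` gives 24.2% in this assay, and compound 3 `COc1ccc(C(=O)Oc2cc3c(C)ccc(C(C)C)c3cc2C)cc1` gives 32.8%. These two values lie within the usual scatter of each other, so nothing separates them. Compound 2 `CC1=CC[C@H](C(C)C)c2cc(C)c(OC(=O)c3cccc(C)c3)cc21` stands apart only in that no figure was reported for it: in this assay compound 2 is recorded as "not active" (no number reported), and so it cannot be placed on the same scale as compound 1 or compound 3, other than that its inhibition was not judged worth a number.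

Compound 4 `CC1=CC[C@H](C(C)C)c2cc(C)c(OC(=O)c3ccc([N+](=O)[O-])cc3)cc21` has not yet been measured. It differs from compound 2 in one place: 4-nitrophenyl in place of 3-methylphenyl on a carbonyl carbon. Among the measured compounds shown here, no measured pair in this set shows what such a change does, so its direction and size cannot be read from any earlier step. With compound 2 reported as "not active" (no number reported) and the two numbered esters sitting in the low-to-moderate range of inhibition, a modest upward move beyond the scatter is plausible for compound 4, but an outcome that again falls below the reporting threshold cannot be ruled out. Compound 4 is therefore expected to give 25% in this assay, with a range of 5% to 45%.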

Compound 4, a percentage reported as inhibition, at one concentration (the size of the read-out at that concentration, not a potency): 47.5%
Compound 4: middle estimate off by 22.5 percentage points, on the low side; measured number above the stated range.
By their numbers in this assay, from the lowest: compounds 1 and 3 (each within the scatter of the next); then compound 4.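

Among the compounds shown here, with the aromatic group on the carbonyl carbon exchanged, this assay gives a number 23.3 percentage points higher from compound 1 to compound 4 (beyond the scatter), so this is the first change at this position that can be read as a step beyond the usual scatter, showing that the aromatic group carried there can alter the inhibition seen on the shared core. Compound 2 is recorded as "not active" (no number reported) in this assay, so the step from it to compound 4 cannot be read, although compound 4 at 47.5% in this assay does have a number where the 3-methylphenyl ester has none. Nothing shown here accounts for the rise in inhibition.

For the compounds shown here, the single step does not separate the contribution of the nitro group from that of where it sits on the ring, and a 3-nitrophenyl ester or a phenyl ring carrying an amine or a carboxylic acid on the same carbonyl carbon would be needed to do so. These figures are also the size of the read-out at one concentration, so they leave open how potency would change across the compounds.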